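This account rests on a few compounds, and the source may have more. Where it says the series, first, only, none or still open, it means among the compounds named here.

Compound 1 `COc1ccc(Sc2nc3cc(N)cc(N)c3nc2-c2ccccc2)cc1`; compound 2 `Nc1cc(N)c2nc(-c3ccccc3)c(Oc3ccc(F)cc3)nc2c1`; compound 3 `Nc1cc(N)c2nc(-c3ccccc3)c(Sc3ccc(F)cc3)nc2c1`.

In a functional assay on OVCAR-3 cells (Homo sapiens) for inhibition, read by sulforhodamine B assay, with a stated time of 48 h (on this read-out higher numbers stand for weaker inhibition of growth and lower numbers for stronger inhibition of growth), compound 2 gives 41700 nM, the only number shown. For compound 1 the value in this assay is a limit, < 100000 nM. Among the measured compounds shown here, the only measured step, a step that the limit leaves unreadable from compound 1 to compound 2, therefore gives no readable size, since one of its two values sits at the limit of < 100000 nM in this assay, at which 1 of the 2 values shown sits. Compound 3 differs from compound 2 by (4-fluorophenyl)sulfanyl in place of 4-fluorophenoxy on an aromatic carbon. Nothing measured speaks to this exchange, so no step beyond the scatter is expected; the estimated change a 1.0-fold lower number from compound 2 to compound 3 (0.02 log units; within the scatter) is small, and compound 3 is expected to give about 40000 nM, between 14000 nM and 100000 nM.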

Compound 3, concentration for total growth inhibition: 33900 nM
For compound 3 the middle estimate is 1.2-fold (0.07 log units) above the measured one, within the range that was stated.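

In this assay, among the compounds shown here, (4-fluorophenyl)sulfanyl in place of 4-fluorophenoxy on this aromatic carbon next to the ring nitrogen gives a 1.2-fold lower number from compound 2 to compound 3 (0.09 log units; within the scatter) and is the first readable exchange at this position. Swapping the oxygen link for sulfur thus leaves the read-out within the scatter. The value of compound 1 is a limit, so the steps from compound 1 cannot be read: the limit of < 100000 nM in this assay, at which 1 of the 3 values shown sits.

As far as these compounds go, whether methoxy or fluoro on the outer ring matters stays open. So does the effect of an amine link at this position.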